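The source may report more compounds than this note shows. Statements on the series, on what has been measured and on what is new or still open speak of the compounds shown alone.

In a functional assay on HeLa cells (Homo sapiens) for cytotoxicity (on this read-out higher numbers stand for lower toxicity in this test and lower numbers for higher toxicity in this test), compound 2 `CCCCCCCC/[N+]([O-])=N/[C@@H](COC)C(N)=O` gives 40.5 ug/mL. Compound 3 `CCCCCC/C=C\[N+]([O-])=N\[C@@H](COC)[C@H](C)O` gives 35.1 ug/mL in this assay, a number within the usual scatter of that of compound 2, so the two cannot be ranked against each other. For compound 1 `COC[C@H](/N=[N+](\[O-])CCCCCCC(C)=O)[C@H](C)O` this assay reports only a limit, > 50 ug/mL, and not a number. Compound 4 `CCCCCCCC/[N+]([O-])=N/[C@@H](COC)[C@H](C)O` has not yet been measured in this assay. It differs from compound 2 by 1-hydroxyethyl in place of carbamoyl on a saturated chain carbon bound to a double-bonded nitrogen and a saturated chain carbon. Compound 3 already carries the same 1-hydroxyethyl group and its value of 35.1 ug/mL sits within the scatter of compound 2, so no step beyond the scatter is expected in either direction. Compound 4 is expected to give about 38 ug/mL, between 20 ug/mL and 70 ug/mL, which means an expected step of a 1.1-fold lower number from compound 2 to compound 4 (0.03 log units; within the scatter).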

Compound 4, half-maximal cytotoxic concentration: 30.5 ug/mL
Compound 4: the middle estimate sits 1.2-fold (0.10 log units) above what was measured, and the stated range covers the measured number.
By their numbers in this assay, from the lowest: compounds 4, 3 and 2 (each within the scatter of the next). At a limit, above all of these: compound 1.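

In this assay, among these compounds, 1-hydroxyethyl in place of carbamoyl on this carbon gives a 1.3-fold lower number from compound 2 to compound 4 (0.12 log units; within the scatter), the first direct reading of this exchange, and compound 2 and compound 4 cannot be ranked against each other. Ethyl in place of acetyl, six bonds along the chain from a double-bonded nitrogen, gives an at least 1.6-fold lower number from compound 1 to compound 4 (0.21 log units; that floor lies within the scatter). The true size of that step stays unknown because compound 1 has a limit, so the step is only a floor: the limit of > 50 ug/mL in this assay, at which 1 of the 4 values shown sits.

Going by these compounds, whether an amine or a carboxylic acid on the same carbon would give a step beyond the scatter remains open. So does the effect of a longer chain.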